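Benzyl versus methyl on the core nitrogen: a pairwise transfer

A few compounds are considered here, and "the series" means these few. Any claim that something is new, unique, unknown or untested is made for them only; others in the source may bear on it.

Three amidines measured in a functional assay on MDA-MB-231 cells (Homo sapiens) for cytotoxicity, read by MTT assay, with a stated time of 72 h (a higher number here means a weaker inhibitor, a lower number a stronger inhibitor), set up one transferable step. Compound 3 `CN1CCN(c2ccc(NC(=N)c3cc4cn(C)nc4cn3)cc2)CC1` gives 20500 nM. Compound 1 `COc1ccc(Cn2cc3cc(C(=N)Nc4ccc(N5CCN(C)CC5)cc4)ncc3n2)cc1` gives 8000 nM. The change between them is 4-methoxyphenyl in place of hydrogen on a saturated chain carbon bound to an aromatic nitrogen, and the step it made is a 2.6-fold lower number from compound 3 to compound 1 (0.41 log units; beyond the scatter). Compound 2 `Cn1nc(-c2ccccc2)c2cc(C(=N)Nc3ccccc3)ncc21`, built on a different core, gives 11100 nM; the difference between the two cores is not broken down here, and the values of compound 2 and compound 1 lie within the scatter of each other, as do those of compound 2 and compound 3.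

Compound 4 `COc1ccc(Cn2nc(-c3ccccc3)c3cc(C(=N)Nc4ccccc4)ncc32)cc1` has not yet been run in this assay. It stands to compound 2 exactly as compound 1 stands to compound 3: the change is 4-methoxyphenyl in place of hydrogen on a saturated chain carbon bound to an aromatic nitrogen, the same change at the same place. The expectation rests on a single pair, so it is carried over with reservation. A step of about a 2.5-fold lower number from compound 2 to compound 4 (0.39 log units; beyond the scatter) is expected from compound 2 to compound 4, because the same change gave a 2.6-fold lower number from compound 3 to compound 1 (0.41 log units; beyond the scatter). On that basis compound 4 is estimated at 4500 nM, with a plausible range from 2000 nM to 10000 nM.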

Compound 4, half-maximal inhibitory concentration: 5400 nM
Compound 4: the middle estimate sits 1.2-fold (0.08 log units) below what was measured; the range from low to high includes it.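

In this assay, the change from methyl to 4-methoxybenzyl gives a 2.1-fold lower number from compound 2 to compound 4 (0.31 log units; beyond the scatter), so the lower number seen on the first core recurs on the second. The two steps also agree in size as far as these pairs can show: the same change on two cores in this assay, a 2.6-fold lower number (0.41 log units; beyond the scatter) from compound 3 to compound 1 and a 2.1-fold lower number (0.31 log units; beyond the scatter) from compound 2 to compound 4, 1.2-fold (0.10 log units) apart, within the scatter of two such steps

This supports carrying the change between these two cores only, with one pair on each, and it does not show that the step would hold on any other core or explain how the change acts on cytotoxicity. The compounds shown leave open how much of the step belongs to the methoxy group and how much to the benzyl unit, as an unsubstituted benzyl does not appear among them. Also open, going by these compounds, is whether other groups at this place, such as a longer alkyl chain or a chain ending in an amine or a carboxylic acid, would give a step of similar size.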